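Swapping tert-butyl for cyclohexyl on a nitro-thiophene chalcone

This account rests on a few compounds, and the source may have more. Where it says the series, first, only, none or still open, it means among the compounds named here.

Measured so far:
- compound 1 `CC(C)(C)c1ccc(C(=O)/C=C/c2ccc([N+](=O)[O-])s2)cc1` gives 8400 nM in an ADME assay on THP-1 cells (Homo sapiens) for cytotoxicity, read by resazurin assay, with a stated time of 72 h; on this read-out lower numbers stand for higher toxicity in this test and higher numbers for lower toxicity in this test
- compound 2 `Cc1ccccc1C(=O)/C=C/c1ccc([N+](=O)[O-])o1` gives 27900 nM in this assay

Compound 1 has the lower of the two numbers, so it is the more toxic of the pair in this assay, and the gap to compound 2 lies beyond the usual scatter. The two differ in several places at once, so no single change can be read from them.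

Compound 3 `O=C(/C=C/c1ccc([N+](=O)[O-])s1)c1ccc(C2CCCCC2)cc1` is compound 1 with one change: cyclohexyl in place of tert-butyl on an aromatic carbon. Among the measured compounds shown here, no measured pair here isolates this kind of change, so there is no guide to its size. The expectation for compound 3 is a step from compound 1 of about a 1.4-fold lower number from compound 1 to compound 3 (0.15 log units; within the scatter), within the scatter or slightly toward a lower number. Compound 3 is therefore estimated at 6000 nM, in a range from 2500 nM to 15000 nM.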

Compound 3, half-maximal cytotoxic concentration: > 50000 nM
Compound 3 ended at the assay's limit (the forecaster's own chance of this, stated with the estimate: 5%); at least 8.3-fold (0.92 log units) between middle value and limit.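

Cyclohexyl in place of tert-butyl on this aromatic carbon, para to a large group, gives an at least 5.9-fold higher number from compound 1 to compound 3 (0.77 log units; beyond the scatter), so in this assay this single change goes with lower toxicity. Among the compounds shown here, compound 1 and compound 2 differ in several places at once, so this is the first sign that the group at this position can by itself shift the number while the rest of the core of compound 1 stays the same. Compound 3 has no exact number, only a limit of the assay, so the full size of the step stays unknown: the limit of > 50000 nM in this assay, at which 1 of the 3 values shown sits.

This one step cannot separate the ring of cyclohexyl from its larger count of carbon atoms. As far as these compounds go, how an amine, a carboxylic acid or a longer chain at the same place would read in this assay also stays open.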